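Replacing Methoxy by Tetrazolyl: An Expected Shift

A few compounds are considered here, and "the series" means these few. Any claim that something is new, unique, unknown or untested is made for them only; others in the source may bear on it.

Values in an assay on HeLa cells with Bile acid receptor (Homo sapiens) as the target, read by a luciferase reporter, with a stated time of 24 h; a higher number here means that more compound is needed for the effect, a lower number that less compound is needed:
compound 1, `CC(C)(C)c1ccc(C(=O)NCc2ccc(C(N)=O)cc2)cc1`: 3800 nM
compound 2, `CC(C)(C)c1ccc(C(=O)NCc2ccc(CCC(=O)O)cc2)cc1`: 350 nM
compound 3, `COc1ccc(CNC(=O)c2ccc(C(C)(C)C)cc2)cc1`: 150 nM

Compound 3 gives the lowest number of the three in this assay; compound 2 is nearest, with a 2.3-fold lower number from compound 2 to compound 3 (0.37 log units; beyond the scatter), and compound 1 is furthest, with a 25-fold lower number from compound 1 to compound 3 (1.40 log units; beyond the scatter). Compound 4, `CC(C)(C)c1ccc(C(=O)NCc2ccc(-c3nnn[nH]3)cc2)cc1`, differs from compound 3 in one place: 1H-tetrazol-5-yl in place of methoxy on an aromatic carbon. Both measured steps that bear on this change lead to methoxy from another substituent and end at a lower number, the modest one from compound 2 and the large one from compound 1. Moving away from methoxy is therefore expected to raise the number, by an amount between those two steps. Relative to compound 3, compound 4 is expected to show a 4.0-fold higher number from compound 3 to compound 4 (0.60 log units; beyond the scatter), with an estimated 600 nM and a range of 150 nM to 2500 nM.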

Compound 4, half-maximal effective concentration: 120 nM
For compound 4 the middle estimate is 5.0-fold (0.70 log units) above the measured one, outside the stated range (below it).
By their numbers in this assay, from the lowest: compounds 4 and 3 (each within the scatter of the next); then compound 2; then compound 1.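

In this assay, on this aromatic carbon para to a large group, 1H-tetrazol-5-yl and methoxy cannot be told apart (a 1.3-fold lower number from compound 3 to compound 4 (0.10 log units; within the scatter)), although the entering group brings a five-membered aromatic ring and a hydrogen-bond donor. The same group stands clear of 2-carboxyethyl (a 2.9-fold lower number from compound 2 to compound 4 (0.46 log units; beyond the scatter)) and of carbamoyl (a 32-fold lower number from compound 1 to compound 4 (1.50 log units; beyond the scatter)). Nothing measured here offers an explanation for this result.

From the compounds shown here alone, it remains open whether a carboxylic acid set directly on this aromatic carbon, or an amine there, would match compound 3 and compound 4. Also open, going by these compounds, is whether a methyl group on the tetrazole nitrogen would change the number.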